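The compounds below may be only part of what the source reports. "The series", "measured", "known", "first", "only" and "open" are said of these compounds alone.

Compound 1 `O=[N+]([O-])c1cc(Nc2nc3nonc3nc2O)ccc1OC(F)(F)F` gives 53500 nM in an assay on mitochondria from L6 cells (Rattus norvegicus) for activation, with a stated time of 90 min; on this read-out higher numbers stand for an effect only at larger amounts of compound and lower numbers for an effect already at smaller amounts. Compound 2 `Oc1nc2nonc2nc1Nc1ccc(OCC(F)(F)F)c(F)c1` gives 10400 nM. Compound 3 `Oc1nc2nonc2nc1Nc1ccc(OCCCC(F)(F)F)c(F)c1` gives 4200 nM.

Compound 3 has the lowest number of the three, with compound 2 the nearest and compound 1 the furthest, both beyond the scatter. Compound 4 `Oc1nc2nonc2nc1Nc1ccc(OC(F)(F)F)c(F)c1` differs from compound 3 in one place: trifluoromethyl in place of 4,4,4-trifluorobutyl on an oxygen on an aromatic ring. Among the compounds with values here, the single step that bears on this is a 2.5-fold lower number from compound 2 to compound 3 (0.39 log units; beyond the scatter), where a longer chain went with a lower number. The change to compound 4 runs the other way and further, removing the chain altogether. Compound 1 carries the same trifluoromethoxy group but differs elsewhere and shows a high number. A modest rise in the number is therefore expected, a 4.8-fold higher number from compound 3 to compound 4 (0.68 log units; beyond the scatter). Compound 4 is estimated at 20000 nM, between 7000 nM and 60000 nM.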

Compound 4, half-maximal effective concentration: 2900 nM
The estimate for compound 4 lay 6.9-fold (0.84 log units) above the measured number; measured number outside the range, below it.
By their numbers in this assay, from the lowest: compounds 4 and 3 (each within the scatter of the next); then compound 2; then compound 1.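

On this oxygen, removing the longer chain changes little: 4,4,4-trifluorobutyl to trifluoromethyl gives (a 1.4-fold lower number from compound 3 to compound 4 (0.16 log units; within the scatter)), which leaves the two groups indistinguishable. Trifluoromethyl in place of 2,2,2-trifluoroethyl gives (a 3.6-fold lower number from compound 2 to compound 4 (0.55 log units; beyond the scatter)), so the number does not follow chain length in a steady line, with compound 2 going against any such trend. The largest step lies elsewhere on the ring, where fluoro in place of nitro gives (an 18-fold lower number from compound 1 to compound 4 (1.27 log units; beyond the scatter)). No measurement here explains these steps. Still open, going by these compounds, is how a longer chain on this oxygen, or an amine in place of the fluoro, would behave.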